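Adding a nitro group to compound 2

The source may report more compounds than this note shows. Statements on the series, on what has been measured and on what is new or still open speak of the compounds shown alone.

Compound 1 (`COc1ccc(-c2sc(C(=O)O)cc2-c2cc(OC)c(OC)c(OC)c2)cc1[N+](=O)[O-]`): 23300 nM
Compound 2 (`COc1ccc(-c2sccc2-c2cc(OC)c(OC)c(OC)c2)cc1`): 5470 nM

In a functional assay on SGC-7901 cells (Homo sapiens) for antiproliferative activity, read by MTT assay, with a stated time of 72 h (on this read-out lower numbers stand for stronger inhibition and higher numbers for weaker inhibition), compound 2 gives 5470 nM and holds the lower of the two numbers. Compound 1 stands at 23300 nM and the gap between them lies beyond the usual scatter. Compound 3 (`COc1ccc(-c2sccc2-c2cc(OC)c(OC)c(OC)c2)cc1[N+](=O)[O-]`) has not yet been measured. It keeps the structure of compound 2 with one change, a nitro in place of hydrogen on an aromatic carbon, ortho to a methoxy group (nitro in place of hydrogen on an aromatic carbon). Going by the values given here, compound 1 also carries a nitro group and gives 23300 nM but no measured pair shows this change alone, so the expectation is loose. No shift beyond the scatter is expected in this assay and the estimated step of a 1.1-fold lower number from compound 2 to compound 3 (0.04 log units; within the scatter) is correspondingly small. Compound 3 is estimated at 5000 nM with an expected range of 1200 nM to 20000 nM around that figure.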

Compound 3, half-maximal inhibitory concentration: 3310 nM
For compound 3 the middle estimate is 1.5-fold (0.18 log units) above the measured one; the measured number falls inside the stated range.
By their numbers in this assay, from the lowest: compounds 3 and 2 (each within the scatter of the next); then compound 1.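

In this assay the step of a 1.7-fold lower number from compound 2 to compound 3 (0.22 log units; within the scatter) stays within the usual scatter, so compound 2 and compound 3 cannot be told apart, and a nitro group ortho to a methoxy group is tolerated on this read-out. The step of a 7.0-fold lower number from compound 1 to compound 3 (0.85 log units; beyond the scatter) lies beyond the scatter, which shows that the weaker number of compound 1 goes with its carboxy group and not with its nitro group. No measurement here explains either step.

Going by these compounds, whether this position would accept other groups in place of the nitro group, such as an amine or a fluorine atom, remains open. On these data alone, it is also open whether an ester or an amide in place of the carboxy group would give a number as high as that of compound 1 23300 nM or one closer to that of compound 3 3310 nM.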